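Chloro to methyl swap in a cytotoxicity series

The compounds below may be only part of what the source reports. "The series", "measured", "known", "first", "only" and "open" are said of these compounds alone.

Compound 1 `O=c1cc(CSc2nc3ccccc3s2)oc2ccc(Cl)cc12` was tested in a functional assay on MCF7 cells (Homo sapiens) for cytotoxicity, read by MTT assay, with a stated time of 72 h; a lower number here means a stronger inhibitor, a higher number a weaker inhibitor. In this assay compound 1 gives only a limit of the assay, > 25000 nM. Compound 3 `Cc1cc(C)n2nc(SCc3cc(=O)c4cc(Cl)ccc4o3)nc2n1` carries the same chloro on another core; the difference between the cores of compound 1 and compound 3 is not broken down here. In this assay compound 3 likewise reaches only a limit, > 25000 nM. Compound 2 `Cc1ccc2oc(CSc3nc4nc(C)cc(C)n4n3)cc(=O)c2c1` arises from compound 3 by methyl in place of chloro on an aromatic carbon. In this assay compound 2 again sits at a limit, > 25000 nM. The step that the two limits leave unreadable from compound 3 to compound 2 cannot be sized because of the limit of > 25000 nM in this assay, at which 3 of the 3 values shown sit.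

Compound 4 `Cc1ccc2oc(CSc3nc4ccccc4s3)cc(=O)c2c1` is not yet measured; it arises from compound 1 by methyl in place of chloro on an aromatic carbon, the same change as from compound 3 to compound 2, at a place described in the same words. In light of a step that the two limits leave unreadable from compound 3 to compound 2, compound 4 is expected to remain at the limit, the expected step being a step that the limit leaves unreadable from compound 1 to compound 4. The estimate for compound 4 is 40000 nM, with a range from 15000 nM to 150000 nM, and a measured number rather than a limit is not expected.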

Compound 4, half-maximal inhibitory concentration: > 25000 nM
Compound 4 gave a limit, no number; the forecaster's own chance of this, stated with the estimate: 85%; the middle value is on the limit's open side.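

No step can be read between compound 1 and compound 4 in this assay, because both stay at a limit and give no number: the limit of > 25000 nM in this assay, at which 4 of the 4 values shown sit.

The compounds shown leave open whether methyl in place of chloro on an aromatic carbon changes cytotoxicity on either core, and how the two cores compare.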